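Solubility of an Imide Series: Swapping the Side Group

The source may hold more compounds than are shown below. What is called first, only, known or untested is meant among the compounds shown, and "the series" means these compounds.

The two compounds with measurements share one imide core. Compound 1 `Cc1nc(C(=O)O)c(N)c2c1C(=O)N(Cc1ccccc1)C2=O` carries a benzyl group and a carboxylic acid, and in a physicochemical assay for solubility, using the shake flask method, in simulated intestinal fluid, measured as kinetic solubility, with a stated time of 2 h, at 25 degrees C, at pH 6.5 (on this read-out higher numbers stand for higher solubility and lower numbers for lower solubility), compound 1 gives 177000 nM. Compound 2 `Cc1noc(-c2nc(C)c3c(c2N)C(=O)N(CC2CCNCC2)C3=O)n1` carries an oxadiazole and a piperidin-4-ylmethyl group, and in this assay compound 2 gives 160000 nM. Among these two numbers compound 2 stands lowest, but its nearest neighbour, compound 1, lies within the scatter of it, so the two cannot be told apart.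

Compound 3 `Cc1noc(-c2nc(C)c3c(c2N)C(=O)N(Cc2ccc(N(C)C)cc2)C3=O)n1` has not yet been measured in this assay. It differs from compound 2 in one place: 4-(dimethylamino)phenyl in place of piperidin-4-yl on a saturated chain carbon bound to an amide-type nitrogen in a ring. For the measured compounds named here, no pair of measured compounds shows this kind of change, so the step has to be judged from the structures alone. The author expects compound 3 to show a lower solubility than compound 2, with the step from the expected move being a 5.3-fold lower number from compound 2 to compound 3 (0.73 log units; beyond the scatter), a decrease that should lie beyond the scatter. Compound 3 is thus expected to give 30000 nM in this assay, within a range from 8000 nM to 120000 nM.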

Compound 3, solubility: 7400 nM
Estimate against measurement, compound 3: 4.1-fold (0.61 log units) above; the whole stated range lies above it.
By their numbers in this assay, from the lowest: compound 3; then compounds 2 and 1 (each within the scatter of the next).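

For the compounds shown here, at this position, on a saturated chain carbon bound to an amide-type nitrogen in a ring, exchanging piperidin-4-yl for 4-(dimethylamino)phenyl in this assay gives a 22-fold lower number from compound 2 to compound 3 (1.33 log units; beyond the scatter) and thus supplies the first comparison in one place, which compounds 1 and 2 could not offer. The step is large, yet the groups differ in several counted ways at once: a six-membered non-aromatic ring with 1 hydrogen-bond donor leaves, and a six-membered aromatic ring of carbon only with 0 hydrogen-bond donors enters, carrying more heavy atoms. No measurement shown here bears on which of these differences accounts for the fall, and its cause remains unassigned.

As far as these compounds go, it remains open whether the fall follows the aromatic ring, the dimethylamino group or the absence of the ring's amine hydrogen, a question that a plain phenyl, a cyclohexyl ring or a 1-methylpiperidin-4-yl group on the same chain carbon could help to separate. From the compounds shown here alone, it is also open whether the same exchange gives a step of similar size when a carboxylic acid stands in place of the oxadiazole on the shared core.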